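This account rests on a few compounds, and the source may have more. Where it says the series, first, only, none or still open, it means among the compounds named here.

In a functional assay on B16-F0 cells (Mus musculus) for inhibition, read by CCK-8 assay, with a stated time of 48 h (a higher number here means a weaker inhibitor, a lower number a stronger inhibitor), compound 1 `COc1cc(-c2ccnc3cc(-c4ccc5ccn(C)c5c4)nn23)cc(OC)c1OC` gives 657 nM and compound 2 `COc1ccc(-c2cc3nccc(-c4cc(OC)c(OC)c(OC)c4)n3n2)cc1` gives 1410 nM as the higher of the two numbers, which makes it the weaker of the pair. Compound 3 `COc1ccc(-c2cc3nccc(-c4cc(OC)c(OC)c(OC)c4)n3n2)cc1F` has fluoro in place of hydrogen on an aromatic carbon of compound 2, ortho to a methoxy group and meta to a large group, the difference being fluoro in place of hydrogen on an aromatic carbon in full. Among the compounds with values here, no measured compound carries fluoro. Within the data shown here, the only measured step is a 2.1-fold higher number from compound 1 to compound 2 (0.33 log units; beyond the scatter) on placing 4-methoxyphenyl where 1-methyl-1H-indol-6-yl stood. That step is modest and belongs to a larger structural change, so no step beyond the scatter is expected in this assay in either direction. The estimated step is a 1.2-fold lower number from compound 2 to compound 3 (0.07 log units; within the scatter) and carries no firm direction. Compound 3 is expected at 1200 nM with an estimated range from 520 nM to 2800 nM for the coming measurement.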

Compound 3, half-maximal inhibitory concentration: 3950 nM
Compound 3: the middle estimate sits 3.3-fold (0.52 log units) below what was measured; the measured number lies above the stated range.
By their numbers in this assay, from the lowest: compound 1; then compound 2; then compound 3.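

In this assay, fluoro in place of hydrogen on the 4-methoxyphenyl ring, ortho to a methoxy group, is not a neutral edit: a single added heavy atom gives a 2.8-fold higher number from compound 2 to compound 3 (0.45 log units; beyond the scatter) and so this place on the ring responds to substitution. The 3-fluoro-4-methoxyphenyl group also stands further from 1-methyl-1H-indol-6-yl than 4-methoxyphenyl does, with a 6.0-fold higher number from compound 1 to compound 3 (0.78 log units; beyond the scatter) and so, among these three, compound 1 keeps the lowest number, its steps to both others being beyond the scatter. Nothing at hand explains why the number rises with fluoro.

On these data alone, whether this rise is particular to fluoro or follows from any group at this place stays open; chloro, methyl, hydroxy or an amine there would begin to separate the two. As far as these compounds go, whether the rise would carry over to a compound with the shared core and a different aryl group, such as the 1-methyl-1H-indol-6-yl of compound 1, also stays open.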